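Swapping tert-butyl for chloro on a shared core

The source may report more compounds than this note shows. Statements on the series, on what has been measured and on what is new or still open speak of the compounds shown alone.

Three compounds have been measured in an assay on mitochondria from L6 cells (Rattus norvegicus) for activation, with a stated time of 90 min; on this read-out lower numbers stand for an effect already at smaller amounts and higher numbers for an effect only at larger amounts of compound:

- compound 1, `Oc1nc2nonc2nc1Nc1ccc(OC(F)(F)F)cc1Cl`: 1400 nM
- compound 2, `Cc1cccc(C)c1Nc1nc2nonc2nc1O`: > 100000 nM
- compound 3, `CC(C)(C)c1ccc(Nc2nc3nonc3nc2O)cc1`: 3900 nM

The value of compound 2 is a limit of this assay, not a number. Of the two numbers, compound 3 stands highest; its nearest neighbour is compound 1, which sits at a lower number, and that gap is beyond the scatter of the assay. Because one of the three values is the limit of > 100000 nM in this assay, at which 1 of the 3 values shown sits, only these two numbers can be compared directly.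

Compound 4, `Oc1nc2nonc2nc1Nc1ccc(Cl)cc1`, has not yet been measured. It differs from compound 3 in one place: chloro in place of tert-butyl on an aromatic carbon. Both compounds keep the same core and the same single ring attached through the amine, so the read-out of compound 4 should mainly tell how this one exchange matters. Going by the values given here, compound 1 also carries a chloro on its ring, together with a trifluoromethoxy group, and reaches a lower number than compound 3, but no single step between the measured compounds isolates the chloro.

Compound 4 is expected to land near compound 3, with a step of a 1.3-fold lower number from compound 3 to compound 4 (0.11 log units; within the scatter) that may not exceed the scatter. The estimate for compound 4 in this assay is 3000 nM, within a range from 800 nM to 12000 nM.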

Compound 4, half-maximal effective concentration: 11700 nM
Beside the measured number, compound 4's estimate is 3.9-fold (0.59 log units) below it, within the range that was stated.
By their numbers in this assay, from the lowest: compound 1; then compound 3; then compound 4. At a limit, above all of these: compound 2.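

Going by these compounds alone, the exchange of tert-butyl for chloro on this aromatic carbon gives a 3.0-fold higher number from compound 3 to compound 4 (0.48 log units; beyond the scatter), a modest step in this assay, and it is the first change in the set that can be read in one place alone. It shows that the read-out is not indifferent to which group sits at this position, even though the shared core and the amine link stay the same. The group that leaves has 4 heavy atoms and the one that enters has 1, while neither brings a ring, a hydrogen-bond donor or acceptor, or a net charge, but nothing measured here gives a reason why this exchange moves the number.

A single step cannot show whether the read-out follows the number of heavy atoms at this position or some other feature of the two groups. An amine or a carboxylic acid on the same aromatic carbon, or a longer chain such as n-butyl, would test how far the position tolerates groups of a different kind, and whether any of them brings the number down.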